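The source may report more compounds than this note shows. Statements on the series, on what has been measured and on what is new or still open speak of the compounds shown alone.

In a functional assay on HCT-116 cells (Homo sapiens) for cytotoxicity, read by MTT assay, with a stated time of 48 h (a lower number here means a stronger inhibitor, a higher number a weaker inhibitor), compound 1 `COc1ccc(NC(=O)c2cn(-c3ccccc3)nc2-c2ccc(C)cc2)cc1` gives 1450 nM and stands highest of the two numbers measured; its nearest neighbour is compound 2 `CCOc1ccc(NC(=O)c2cn(-c3ccccc3)nc2-c2ccc(C)cc2)cc1`, which gives 780 nM, and the step of a 1.9-fold lower number from compound 1 to compound 2 (0.27 log units; within the scatter) is within the scatter. Compound 3 `COc1ccc(NC(=O)c2cn(-c3ccccc3)nc2-c2ccc(Cl)cc2)cc1` has not yet been measured; it differs from compound 1 by chloro in place of methyl on an aromatic carbon. Among the measured compounds shown here, the only measured step concerns the ethoxy chain on the other side of the shared core, and no measured step bears on an exchange at the 4-methylphenyl ring, so the data give no direction for this change. Compound 3 is therefore expected to sit close to compound 1, with no step beyond the scatter, the expected step being a 1.2-fold lower number from compound 1 to compound 3 (0.08 log units; within the scatter). The estimate for compound 3 in this assay is 1200 nM, within a range of 400 nM to 3600 nM.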

Compound 3, half-maximal inhibitory concentration: 1330 nM
Beside the measured number, compound 3's estimate is 1.1-fold (0.04 log units) below it, and the stated range covers the measured number.
By their numbers in this assay, from the lowest: compounds 2, 3 and 1 (each within the scatter of the next).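

In this assay, among the compounds shown here, the exchange of 4-methylphenyl to 4-chlorophenyl gives the first reading at this position, and the step is a 1.1-fold lower number from compound 1 to compound 3 (0.04 log units; within the scatter). On the core of compound 1, methyl and chloro on this aromatic carbon therefore cannot be told apart, something the earlier step on the chain bound to the oxygen could not show. No evidence is at hand that bears on this result.

The compounds shown leave open whether this position stays as insensitive with groups of another kind, such as an amine or a carboxylic acid, on the same carbon. They also leave open whether chloro reads the same when the ethoxy group of compound 2 stands on the other side of the shared core.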